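Ester Variation and Stability in Buffer

This account rests on a few compounds, and the source may have more. Where it says the series, first, only, none or still open, it means among the compounds named here.

compound 1 `C[C@@H](O)[C@H]1C(=O)N2C(C(=O)OCOC(=O)OC(C)(C)C)=C(S[C@@H]3CN[C@H](C(=O)Nc4cccc(C(=O)O)c4)C3)[C@H](C)[C@H]12`: > 95%
compound 2 `CCCCCCCCCCCCCCCCOC(=O)C1=C(S[C@@H]2CN[C@H](C(=O)Nc3cccc(C(=O)OCCCCCCCCCCCCCCCC)c3)C2)[C@H](C)[C@@H]2[C@@H]([C@@H](C)O)C(=O)N12`: > 95%
compound 3 `Cc1oc(=O)oc1COC(=O)c1cccc(NC(=O)[C@@H]2C[C@H](SC3=C(C(=O)O)N4C(=O)[C@H]([C@@H](C)O)[C@H]4[C@H]3C)CN2)c1`: > 95%

In a physicochemical assay for metabolic stability, read by LC-MS, in phosphate buffer, with a stated time of 3 h, at pH 7.4, tested at 50 uM (on this read-out higher numbers stand for a more stable compound and lower numbers for a less stable compound), compound 1 gives > 95%, which is a limit of the assay and not a number. Compound 2 gives > 95% in this assay, also a limit. Compound 3 gives > 95% in this assay, again a limit. Because of the limit of > 95% in this assay, at which 3 of the 3 values shown sit, no ordering among the three can be read from this assay, and compound 1 stands where the other two stand, at the limit.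

Compound 4 `C[C@@H](O)[C@H]1C(=O)N2C(C(=O)OCC(F)(F)F)=C(S[C@@H]3CN[C@H](C(=O)Nc4cccc(C(=O)O)c4)C3)[C@H](C)[C@H]12` has not yet been measured in this assay. It differs from compound 1 in one place: trifluoromethyl in place of (tert-butoxycarbonyl)oxy on a saturated chain carbon bound to an oxygen next to a carbonyl group. Among the compounds with values here, no measured step between two compounds differing in a single place is available to size this change. The account therefore expects the step from compound 1 to compound 4 to be a step that the limit leaves unreadable from compound 1 to compound 4, that is, no change beyond the usual scatter. Compound 4 is estimated at 96% in this assay, within a range from 88% to 100%, and the result is expected to come back as a limit once more.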

Compound 4, percent of the compound remaining: > 95%
Compound 4: only a limit was reported (the forecaster's own chance of this, stated with the estimate: 85%); the middle value does not contradict the limit.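

No step can be read from compound 1 to compound 4 in this assay, because the values of both compounds are limits and not numbers: the limit of > 95% in this assay, at which 4 of the 4 values shown sit.

The compounds shown leave open whether changing the ester group alters the percent remaining in this assay at all.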